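This account rests on a few compounds, and the source may have more. Where it says the series, first, only, none or still open, it means among the compounds named here.

Measured so far in a functional assay on T47D cells (Homo sapiens) for cytotoxicity, read by CCK-8 assay; on this read-out higher numbers stand for weaker inhibition and lower numbers for stronger inhibition:

compound 1, `Oc1ccc(-c2cc(-c3ccsc3)cc(-c3cccc(O)c3)n2)cc1`, 760 nM
compound 2, `Oc1ccc(-c2cc(-c3ccsc3)cc(-c3ccc(O)cc3)n2)cc1`, 1770 nM
compound 3, `Oc1cccc(-c2cc(-c3cccnc3)cc(-c3ccccc3O)n2)c1`, 6230 nM

Compound 1 and compound 2 share a core and differ by 4-hydroxyphenyl in place of 3-hydroxyphenyl on an aromatic carbon. This gave a 2.3-fold higher number from compound 1 to compound 2 (0.37 log units; beyond the scatter). Compound 3 has the highest of the three numbers; the difference between the core of compound 1 and the core of compound 3 is not broken down here, so what separates their values is only read from the two values themselves.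

Compound 4, `Oc1ccc(-c2cc(-c3cccnc3)cc(-c3ccccc3O)n2)cc1`, is not yet measured in this assay. It differs from compound 3 by 4-hydroxyphenyl in place of 3-hydroxyphenyl on an aromatic carbon. This is the same kind of change as from compound 1 to compound 2, not the same: in compound 1 the place is meta to a 4-hydroxyphenyl group and meta to a thiophen-3-yl group, in compound 3 it is meta to a 2-hydroxyphenyl group and meta to a pyridin-3-yl group. The expectation for compound 4 rests on one earlier step, a 2.3-fold higher number from compound 1 to compound 2 (0.37 log units; beyond the scatter), and is expected to be of similar size and direction, a 1.9-fold higher number from compound 3 to compound 4 (0.28 log units; within the scatter), with wider uncertainty because the surroundings of the place differ. Compound 4 is therefore estimated at 12000 nM, expected between 4500 nM and 32000 nM.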

Compound 4, half-maximal inhibitory concentration: > 50000 nM
Compound 4: a limit, no number; the forecaster's own chance of this, stated with the estimate: 15%; at least 4.1-fold (0.61 log units) between middle value and limit.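

In this assay compound 4 reads > 50000 nM, which is a limit of the assay and not a number. The change from 3-hydroxyphenyl to 4-hydroxyphenyl gives an at least 8.0-fold higher number from compound 3 to compound 4 (0.90 log units; beyond the scatter), so it raises the number on both cores but does not carry over at one size: the same change on two cores in this assay, a 2.3-fold higher number (0.37 log units; beyond the scatter) from compound 1 to compound 2 and an at least 8.0-fold higher number (0.90 log units; beyond the scatter) from compound 3 to compound 4, at least 3.4-fold (0.53 log units) apart, beyond the scatter of two such steps. Going by these compounds alone, with only two cores, and the second step known only as a minimum, the true size of the step on the core of compound 3 remains unknown, and nothing here shows why the two steps differ.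

Still open is whether the larger step goes with the pyridin-3-yl group or with the 2-hydroxyphenyl group, as these two features of the core of compound 3 are not separated by any pair shown. Also open, on these data alone, is how the series would respond to an amine or a carboxylic acid in place of the hydroxyl group on the changed ring.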